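Cyclopropylcarbonyl to Vinylcarbonyl on a Trimethoxyphenyl Amide

The source may report more compounds than this note shows. Statements on the series, on what has been measured and on what is new or still open speak of the compounds shown alone.

Measured so far:
compound 1 `COc1ccc(CN(C(=O)C2CC2)c2cc(OC)c(OC)c(OC)c2)cc1O` gives 49 nM in a functional assay on HCT-116 cells (Homo sapiens) for inhibition, read by MTT assay, with a stated time of 48 h; on this read-out lower numbers stand for stronger inhibition and higher numbers for weaker inhibition;
compound 2 `COc1ccc(CNc2cc(OC)c(OC)c(OC)c2)cc1` gives 18400 nM in this assay.

Among the compounds with values here, compound 1 stands lowest of the two numbers; the only other value, from compound 2, is far higher, a gap well beyond the scatter. Compound 3 `C=CC(=O)N(Cc1ccc(OC)c(O)c1)c1cc(OC)c(OC)c(OC)c1` differs from compound 1 in one place: vinyl in place of cyclopropyl on a carbonyl carbon. Within the data shown here, no comparable step between measured compounds is known, so any expectation rests on compound 1 alone. Compound 3 is expected to stay close to compound 1, with a step of a 1.2-fold lower number from compound 1 to compound 3 (0.09 log units; within the scatter) no larger than the scatter, or a small gain. Compound 3 is therefore estimated at 40 nM, ranging from 10 nM to 160 nM.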

Compound 3, half-maximal inhibitory concentration: 98 nM
Compound 3: the middle estimate sits 2.5-fold (0.39 log units) below what was measured, within the range that was stated.
By their numbers in this assay, from the lowest: compounds 1 and 3 (each within the scatter of the next); then compound 2.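

In this assay, vinyl in place of cyclopropyl on the carbonyl carbon gives a 2.0-fold higher number from compound 1 to compound 3 (0.30 log units; within the scatter) and so leaves compound 3 indistinguishable from compound 1. This position therefore accepts an open vinyl group with a double bond as well as the three-membered ring, so the ring itself is not required for a value in this range. Nothing available explains this result. On these data alone, what an ethyl group, a longer chain or an amine on this carbonyl carbon would give remains open, and one step cannot show whether the tolerance extends beyond these two groups.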